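The compounds below may be only part of what the source reports. "The series", "measured", "known", "first", "only" and "open" are said of these compounds alone.

Measured compounds:
- compound 1, `CC(O)(C[S+]([O-])c1ccc(F)c(F)c1)C(=O)Nc1ccc([N+](=O)[O-])cc1C(F)(F)F`, in a functional assay on LNCaP cells (Homo sapiens) for antiproliferative activity (on this read-out higher numbers stand for weaker inhibition and lower numbers for stronger inhibition), gives > 100000 nM; > 100000 nM (2 entries)
- compound 2, `CC(O)(C[S+]([O-])c1ccc(OC(F)(F)F)cc1)C(=O)Nc1ccc([N+](=O)[O-])cc1C(F)(F)F`, in this assay gives > 100000 nM

Both entries for compound 1 in this assay are limits of the assay and not numbers. The entry for compound 2 in this assay is likewise a limit, so compound 2 stands only at the edge of what the assay reports: the limit of > 100000 nM in this assay, at which 1 of the 2 values shown sits. Among the compounds with values here, no step between two measured compounds with single numbers is available, so the data give no measured response of the series to any structural change.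

Compound 3, `CC(O)(C[S+]([O-])c1ccc(C(F)(F)F)cc1)C(=O)Nc1ccc([N+](=O)[O-])cc1C(F)(F)F`, is not yet measured. It differs from compound 2 by trifluoromethyl in place of trifluoromethoxy on an aromatic carbon. With both measured compounds at the limit, the step expected in this assay is a step that the limit leaves unreadable from compound 2 to compound 3, none beyond the scatter. Compound 3 is expected to give 150000 nM in this assay, within 30000 nM to 1000000 nM, and most probably to be reported only as a limit.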

Compound 3, half-maximal inhibitory concentration: 25600 nM
Estimate against measurement, compound 3: 5.9-fold (0.77 log units) above, outside the stated range (below it).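

In this assay the change from 4-(trifluoromethoxy)phenyl to 4-(trifluoromethyl)phenyl gives the only single number among the compounds shown, with an at least 3.9-fold lower number from compound 2 to compound 3 (0.59 log units; beyond the scatter) as the step. This position, on an aromatic carbon para to a large group, therefore responds to a change of substituent, which the limits alone could not show. The true size of the step stays unknown because one end of it is not a number: the limit of > 100000 nM in this assay, at which 1 of the 3 values shown sits.

The compounds shown leave open whether this response is particular to trifluoromethyl or also appears with other groups at this position, such as a nitrile or an amine. Within the data shown here, with a single numerical value, no step between two numbers is available, and no trend across substituents can be stated.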